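A Shorter Chain Carrying an Ether Oxygen

This account rests on a few compounds, and the source may have more. Where it says the series, first, only, none or still open, it means among the compounds named here.

In a functional assay on U-937 cells (Homo sapiens) for inhibition, read by MTT assay, with a stated time of 48 h (on this read-out lower numbers stand for stronger inhibition and higher numbers for weaker inhibition), compound 1 `O=C(CCCCOc1no[n+]([O-])c1S(=O)(=O)c1ccccc1)NO` gives 2910 nM and compound 2 `O=C(CCCCCCCOc1no[n+]([O-])c1S(=O)(=O)c1ccccc1)NO` gives 9300 nM as the higher of the two numbers. Compound 3 `O=C(COCCOc1no[n+]([O-])c1S(=O)(=O)c1ccccc1)NO` has not yet been measured. It differs from compound 2 in one place ((hydroxycarbamoyl)methoxy in place of 5-(hydroxycarbamoyl)pentyl on a saturated chain carbon, two bonds along the chain from an oxygen on an aromatic ring), with (hydroxycarbamoyl)methoxy in place of 5-(hydroxycarbamoyl)pentyl on a saturated chain carbon, two bonds along the chain from an oxygen on an aromatic ring. Within the data shown here, only one measured step bears on this (a 3.2-fold higher number from compound 1 to compound 2 (0.50 log units; beyond the scatter)), and it came with a longer chain. Among the measured compounds shown here, a shorter chain might therefore be expected to reverse much of that step, although no measured compound has an oxygen within its chain. In this assay the expected outcome is a 2.1-fold lower number from compound 2 to compound 3 (0.32 log units; beyond the scatter) for this change. Compound 3 is estimated at 4500 nM with an expected range from 1500 nM to 13000 nM overall.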

Compound 3, half-maximal inhibitory concentration: 8150 nM
Compound 3: middle estimate off by 1.8-fold (0.26 log units), on the low side, within the range that was stated.
By their numbers in this assay, from the lowest: compound 1; then compounds 3 and 2 (each within the scatter of the next).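

In this assay, (hydroxycarbamoyl)methoxy in place of 5-(hydroxycarbamoyl)pentyl gives a 1.1-fold lower number from compound 2 to compound 3 (0.06 log units; within the scatter), so at this saturated chain carbon the exchange leaves the two compounds indistinguishable. Set against 2-(hydroxycarbamoyl)ethyl, the same group gives a 2.8-fold higher number from compound 1 to compound 3 (0.45 log units; beyond the scatter), which shows that a chain with fewer heavy atoms than that of compound 2 does not match compound 1 when it carries this oxygen. No information is available on why these numbers fall as they do.

Chain length and the oxygen change together in compound 3, so the compounds shown do not tell which of the two goes with its number. On these data alone, how an amine within the chain, or an all-carbon chain matching that of compound 3, would read also stays open.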